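Amide aryl swap on the carbonyl: benzofuran to indole

This account rests on a few compounds, and the source may have more. Where it says the series, first, only, none or still open, it means among the compounds named here.

Measured compounds:
compound 1 `CCc1ccc(C(=O)NC[C@H]2c3[nH]c4ccccc4c3C[C@H]3[C@H]4c5[nH]c6ccccc6c5C[C@@H]([C@H](C#N)N23)N4C)cc1` — 660 nM
compound 2 `CN1[C@@H]2c3[nH]c4ccccc4c3C[C@H]1[C@H](C#N)N1[C@@H](CNC(=O)c3ccc4ccccc4n3)c3[nH]c4ccccc4c3C[C@@H]21` — 80 nM
compound 3 `CN1[C@@H]2c3[nH]c4ccccc4c3C[C@H]1[C@H](C#N)N1[C@@H](CNC(=O)c3cc4ccccc4o3)c3[nH]c4ccccc4c3C[C@@H]21` — 210 nM

In a functional assay on BGC-823 cells (Homo sapiens) for cytotoxicity, read by MTT assay, with a stated time of 72 h (a lower number here means a stronger inhibitor, a higher number a weaker inhibitor), compound 3 gives 210 nM, the second highest of the three numbers. Its nearest neighbour is compound 2, and the gap is a 2.6-fold higher number from compound 2 to compound 3 (0.42 log units; beyond the scatter). The furthest is compound 1, reached by a 3.1-fold lower number from compound 1 to compound 3 (0.50 log units; beyond the scatter) in the other direction. All three compounds share the same core and differ only in the group on the amide carbonyl carbon.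

Compound 4 `CN1[C@@H]2c3[nH]c4ccccc4c3C[C@H]1[C@H](C#N)N1[C@@H](CNC(=O)c3cc4ccccc4[nH]3)c3[nH]c4ccccc4c3C[C@@H]21` is the next step from compound 3: 1H-indol-2-yl in place of 1-benzofuran-2-yl on a carbonyl carbon. Within the data shown here, no measured step exchanges one bicyclic group for another of the same ring pattern, so nothing bears on this change directly. What does bear on it is how compound 3 itself was reached: a 3.1-fold lower number from compound 1 to compound 3 (0.50 log units; beyond the scatter) and a 2.6-fold higher number from compound 2 to compound 3 (0.42 log units; beyond the scatter) are both modest, and the whole series spans a narrow range. A change that keeps the ring sizes and atom count while turning an acceptor into a donor is therefore expected to move this assay little, in either direction, with no step beyond the scatter anticipated.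

For compound 4 the expected value in this assay is 200 nM, with a range of 80 nM to 500 nM. That estimate corresponds to a 1.1-fold lower number from compound 3 to compound 4 (0.02 log units; within the scatter).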

Compound 4, half-maximal inhibitory concentration: 1690 nM
Beside the measured number, compound 4's estimate is 8.5-fold (0.93 log units) below it; the whole stated range lies below it.
By their numbers in this assay, from the lowest: compound 2; then compound 3; then compound 1; then compound 4.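

In this assay this position proves sensitive to a single ring-atom exchange: 1H-indol-2-yl in place of 1-benzofuran-2-yl keeps the heavy-atom count and ring pattern, yet gives an 8.0-fold higher number from compound 3 to compound 4 (0.91 log units; beyond the scatter) and so moves compound 4 to the top of the numbers in the series. Against the quinolin-2-yl amide the gap widens to a 21-fold higher number from compound 2 to compound 4 (1.32 log units; beyond the scatter) and is the largest step so far, while a 2.6-fold higher number from compound 1 to compound 4 (0.41 log units; beyond the scatter) places compound 4 even higher than the 4-ethylphenyl amide, so a two-ring group on the carbonyl carbon does not by itself give a lower number than 4-ethylphenyl, with compound 4 going against compound 2 and compound 3. Nothing on hand accounts for the size of this step.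

Going by these compounds, whether the rise goes with the hydrogen on the ring nitrogen of 1H-indol-2-yl remains open, and 1-methyl-1H-indol-2-yl or 1-benzothiophen-2-yl on the same carbonyl carbon would bear on that. Also open, on these data alone, is whether the low number of compound 2 is particular to quinolin-2-yl, which isoquinolin-3-yl or quinolin-3-yl at this place would help to settle.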